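The source may report more compounds than this note shows. Statements on the series, on what has been measured and on what is new or still open speak of the compounds shown alone.

In an ADME assay on Vero cells (Chlorocebus sabaeus) for cytotoxicity, read by sulforhodamine B assay, with a stated time of 72 h (on this read-out lower numbers stand for stronger inhibition and higher numbers for weaker inhibition), compound 1, whose structure is `CN1Cc2ccc(OCc3ccccc3)cc2[C@@H](O)C1`, sits at the limit of the assay, reported as > 100000 nM; this is a limit and not a number. Compound 2, with the structure `CN1Cc2ccc(OCc3ccc(-c4ccccc4)cc3)cc2[C@@H](O)C1`, is the only one of the three measured compounds to give a numerical value, 23000 nM in this assay. Compound 3, drawn as `COc1ccc(COc2ccc3c(c2)[C@@H](O)CN(C)C3)cc1`, is again reported at a limit, with > 50000 nM in this assay. The measured steps give an at least 4.3-fold lower number from compound 1 to compound 2 (0.63 log units; beyond the scatter), then a step that the two limits leave unreadable from compound 1 to compound 3, and finally an at least 2.1-fold higher number from compound 2 to compound 3 (0.33 log units; beyond the scatter).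

Compound 4, the structure `Cc1ccccc1COc1ccc2c(c1)[C@@H](O)CN(C)C2`, has not yet been measured in this assay. Compared with compound 1 it shows (methyl in place of hydrogen on an aromatic carbon). Within the data shown here, the only measured step that moved the number beyond the scatter was the entry of phenyl from compound 1 to compound 2, a far larger group than methyl; the entry of methoxy from compound 1 to compound 3 left a step the two limits do not resolve. A single methyl is therefore expected to leave compound 4 close to where compound 1 stands, with no step beyond the scatter, so the expected step is a number no higher from compound 1 to compound 4 (the limit leaves the size open). Compound 4 is thus estimated at 100000 nM, in the range from 40000 nM to 300000 nM, most likely reported again as a limit.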

Compound 4, half-maximal inhibitory concentration: > 100000 nM
Compound 4: only a limit was reported; the forecaster's own chance of this, stated with the estimate: 70%; the middle value lies on the limit itself.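

Compound 1 and compound 4 are both reported in this assay only as limits and not as numbers, so no step can be read between them. The compounds shown leave open how far either compound lies beyond its limit, and whether methyl in place of hydrogen changes the number at all.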